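The source may report more compounds than this note shows. Statements on the series, on what has been measured and on what is new or still open speak of the compounds shown alone.

Compound 1 `O=C(c1ccccc1Cl)N1CCN(c2nc(=O)c3cc(C(F)(F)F)cc([N+](=O)[O-])c3s2)CC1`: in an ADME assay on Vero cells (Chlorocebus sabaeus) for cytotoxicity, read by MTT assay, with a stated time of 72 h (on this read-out higher numbers stand for lower toxicity in this test and lower numbers for higher toxicity in this test), compound 1 sits at the limit > 125000 nM.
Compound 2 `CCCCC(=O)N1CCN(c2nc(=O)c3cc(C(F)(F)F)cc([N+](=O)[O-])c3s2)CC1`: in this assay compound 2 sits at the limit > 125000 nM.

Compound 2 therefore stands only at a limit in this assay, with no number to place it. Among the compounds with values here, the one measured step, a step that the two limits leave unreadable from compound 1 to compound 2, is unreadable, since both of its values rest at the limit (the limit of > 125000 nM in this assay, at which 2 of the 2 values shown sit). Within the data shown here, the change to compound 3 `O=C(c1cccc(F)c1)N1CCN(c2nc(=O)c3cc(C(F)(F)F)cc([N+](=O)[O-])c3s2)CC1` is 3-fluorophenyl in place of butyl on a carbonyl carbon, and no measured step speaks to its effect. Compound 3 is thus expected to stay at the limit as well, the expected step of a number no higher from compound 2 to compound 3 (the limit leaves the size open) lying within the scatter. Compound 3 is estimated in this assay at 125000 nM, between 60000 nM and 250000 nM.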

Compound 3, half-maximal cytotoxic concentration: > 125000 nM
Compound 3: no number, only a limit; the forecaster's own chance of this, stated with the estimate: 85%; the middle value sits exactly at the limit.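

In this assay, within the data shown here, compound 3 stands only at a limit, as do compound 1 and compound 2, so no step among them can be read: the limit of > 125000 nM in this assay, at which 3 of the 3 values shown sit.
As far as these compounds go, whether butyl, 2-chlorophenyl and 3-fluorophenyl on the carbonyl carbon differ at all in this assay stays open.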